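Aryl swap on the fused core of compound 1

The source may report more compounds than this note shows. Statements on the series, on what has been measured and on what is new or still open speak of the compounds shown alone.

Going by the values given here, compound 1 `CC(c1ccc(-c2ccccc2)c(F)c1)c1nnc2n1N=C(c1ccc(Cl)cc1Cl)CS2` stands lowest of the three numbers so far: in a functional assay on MCF7 cells (Homo sapiens) for inhibition, read by sulforhodamine B assay, with a stated time of 72 h (on this read-out lower numbers stand for stronger inhibition and higher numbers for weaker inhibition), compound 1 gives 7600 nM. Compound 2 `COc1ccc2cc(C(C)c3nnc4n3N=C(c3ccc(F)cc3)CS4)ccc2c1` gives 15800 nM in this assay, a higher number beyond the scatter against compound 1, and compound 3 `COc1ccc2cc(C(C)c3n[nH]c(=S)n3N)ccc2c1` gives 22300 nM, also higher than compound 1 beyond the scatter. Compound 4 `Cc1ccc(C2=Nn3c(nnc3C(C)c3ccc(-c4ccccc4)c(F)c3)SC2)cc1` is not yet measured; it differs from compound 1 by 4-methylphenyl in place of 2,4-dichlorophenyl on a carbon with a double bond to nitrogen. Among the compounds with values here, no measured pair shows this change. The step from compound 1 to compound 4 in this assay is expected to be modest, toward a higher number and possibly not beyond the scatter, as a 1.4-fold higher number from compound 1 to compound 4 (0.16 log units; within the scatter). Compound 4 is expected at 11000 nM, within 3500 nM to 35000 nM.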

Compound 4, half-maximal inhibitory concentration: 5000 nM
For compound 4 the middle estimate is 2.2-fold (0.34 log units) above the measured one; the measured number falls inside the stated range.
By their numbers in this assay, from the lowest: compounds 4 and 1 (each within the scatter of the next); then compounds 2 and 3 (each within the scatter of the next).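

In this assay, 4-methylphenyl in place of 2,4-dichlorophenyl on a carbon with a double bond to nitrogen, with the rest of the structure held fixed, gives a 1.5-fold lower number from compound 1 to compound 4 (0.18 log units; within the scatter) on this one pair. At this position, then, both chlorine atoms can leave and a methyl can enter with no change that stands clear of the scatter. Nothing at hand bears on why the two aryl groups read alike.

Open, as far as these compounds go, is whether an amine or a carboxylic acid on this phenyl ring would read alike. Also open, from the compounds shown here alone, is whether the same exchange reads alike on the core of compound 2.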